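Isoquinoline Replaces Isoquinolinone on the Urea Nitrogen

This account rests on a few compounds, and the source may have more. Where it says the series, first, only, none or still open, it means among the compounds named here.

Measured so far in an assay on CHO cells for displacement of a labelled ligand from transient receptor potential cation channel subfamily V member 1 (Homo sapiens), read by scintillation counting, with a stated time of 60 min; on this read-out lower numbers stand for stronger inhibition and higher numbers for weaker inhibition:
- compound 1, `CN(C)C1(Cc2ccccc2)CCN(c2cc(C(F)(F)F)ccc2CNC(=O)Nc2ccc(NS(C)(=O)=O)c(F)c2)CC1`: 1160 nM
- compound 2, `CN(C)C1(Cc2ccccc2)CCN(c2cc(C(F)(F)F)ccc2CNC(=O)Nc2ccc3c(c2)OCC3)CC1`: 41.4 nM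
- compound 3, `CN(C)C1(Cc2ccccc2)CCN(c2cc(C(F)(F)F)ccc2CNC(=O)Nc2cccc3c(=O)[nH]ccc23)CC1`: 111 nM

Compound 3 holds the second highest of the three numbers in this assay. Its nearest neighbour is compound 2, reached by a 2.7-fold higher number from compound 2 to compound 3 (0.43 log units; beyond the scatter), and its furthest is compound 1, from which it is separated by a 10-fold lower number from compound 1 to compound 3 (1.02 log units; beyond the scatter). The remaining measured step, a 28-fold lower number from compound 1 to compound 2 (1.45 log units; beyond the scatter), is the largest in the set.

Compound 4, `CN(C)C1(Cc2ccccc2)CCN(c2cc(C(F)(F)F)ccc2CNC(=O)Nc2ccc3cnccc3c2)CC1`, differs from compound 3 only on the amide-type nitrogen: a group of 10 heavy atoms (9 carbon, 1 nitrogen; one six-membered aromatic ring of carbon only, one six-membered aromatic ring with 1 hetero atom) in place of a group of 11 heavy atoms (9 carbon, 1 nitrogen, 1 oxygen; one six-membered aromatic ring of carbon only, one six-membered aromatic ring with 1 hetero atom), on an amide-type nitrogen. All three measured steps alter this same position, so all of them bear on the change, but none of them swaps an isoquinolinone for an isoquinoline. What they do show is that the group on this nitrogen can move the number across a wide span, and that the lone group in the set without a hydrogen-bond donor, in compound 2, gives the lowest number. The group entering in compound 4 likewise carries no donor. Compound 4 is therefore expected to step modestly downward, a 2.0-fold lower number from compound 3 to compound 4 (0.30 log units; within the scatter), an expectation that sits near the edge of the scatter. The estimate for compound 4 in this assay is 55 nM, with a range from 15 nM to 200 nM.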

Compound 4, inhibition constant: 62 nM
For compound 4 the middle estimate is 1.1-fold (0.05 log units) below the measured one; the measured number falls inside the stated range.
By their numbers in this assay, from the lowest: compounds 2, 4 and 3 (each within the scatter of the next, the first and the last beyond it); then compound 1.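

In this assay, isoquinolin-6-yl enters with no hydrogen-bond donor where the group of compound 3 has one, yet the step (a 1.8-fold lower number from compound 3 to compound 4 (0.25 log units; within the scatter)) stays within the scatter, so this pair does not show that losing the donor from the group on the amide-type nitrogen changes the number. Compound 4 also cannot be told apart from compound 2 (a 1.5-fold higher number from compound 2 to compound 4 (0.18 log units; within the scatter)), which means that two differently built groups, one with a five-membered non-aromatic ring and the other with a six-membered aromatic ring holding a hetero atom, are equivalent on this read-out within the scatter. The one clear separation is from the 3-fluoro-4-(methanesulfonamido)phenyl group (a 19-fold lower number from compound 1 to compound 4 (1.27 log units; beyond the scatter)), so isoquinolin-6-yl joins the groups of compound 2 and compound 3 in lying well apart from compound 1.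

Going by these compounds, whether naphthalen-2-yl, which has no ring nitrogen, or an amine added to the isoquinolin-6-yl group would move the number beyond the scatter from that of compound 4 remains open. Nothing shown here gives a reason for any of these steps.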